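From hydroxy to phenyl on the chloro analogue

The compounds below may be only part of what the source reports. "The series", "measured", "known", "first", "only" and "open" are said of these compounds alone.

In a functional assay on MDA-N cells (Homo sapiens) for inhibition, read by sulforhodamine B assay, with a stated time of 48 h (a lower number here means a stronger inhibitor of growth, a higher number a weaker inhibitor of growth), compound 1 `N#Cc1c(-c2nnc(O)c3nn(-c4ccccc4)cc23)nn(-c2ccccc2)c1-c1ccccc1` gives 13800 nM. Compound 2 `N#Cc1c(-c2nnc(O)c3nn(-c4ccc(Cl)cc4)cc23)nn(-c2ccccc2)c1-c1ccccc1` has chloro in place of hydrogen on an aromatic carbon, and in this assay compound 2 gives > 100000 nM. That value is a limit of the assay and not a number. The standing of compound 2 therefore rests on (the limit of > 100000 nM in this assay, at which 1 of the 2 values shown sits).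

Compound 3 `N#Cc1c(-c2nnc(-c3ccccc3)c3nn(-c4ccc(Cl)cc4)cc23)nn(-c2ccccc2)c1-c1ccccc1` keeps the chloro and has phenyl in place of hydroxy on an aromatic carbon, next to the ring nitrogen: phenyl in place of hydroxy on an aromatic carbon. No measured change touches the hydroxy. For the measured compounds named here, the only guide to size is an at least 7.2-fold higher number from compound 1 to compound 2 (0.86 log units; beyond the scatter), which shows that a single change on the shared core can move the read-out beyond the scatter. With compound 2 at a limit, only a move to a lower number could be read as a value, and a second limit remains a real possibility. The expected change is an at least 2.5-fold lower number from compound 2 to compound 3 (0.39 log units; beyond the scatter), of modest size and poorly constrained. For compound 3 the estimated value is 40000 nM, with an expected range of 10000 nM to 100000 nM.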

Compound 3, concentration for 50% growth inhibition: 63800 nM
Estimate against measurement, compound 3: 1.6-fold (0.20 log units) below, and the stated range covers the measured number.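

In this assay compound 2 gives > 100000 nM, a limit of the assay and not a number. With phenyl in place of hydroxy on the same chloro analogue, compound 3 gives 63800 nM in this assay, so this position accepts a six-membered aromatic ring of carbon only, with the hydroxy and its hydrogen-bond donor gone, and still returns a measurable growth inhibition. The change amounts to an at least 1.5-fold lower number from compound 2 to compound 3 (0.19 log units; that floor lies within the scatter), so a real gain from phenyl is not established, and any reading of its size rests on one limit: the limit of > 100000 nM in this assay, at which 1 of the 3 values shown sits.

Open, from the compounds shown here alone, is how phenyl at this position reads on the core of compound 1, which carries hydrogen in place of the chloro, and so whether the chloro and the group at this position act independently of each other. Also open, going by these compounds, is whether a smaller replacement for hydroxy at this position, such as an amine or a methoxy group, would give a value on the same scale as compound 3 or stay at a limit.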